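Methoxy to Chloro Carried Across Two Related Cores

The source may hold more compounds than are shown below. What is called first, only, known or untested is meant among the compounds shown, and "the series" means these compounds.

Of the compounds shown here, three with related cores have been measured in a functional assay on PC-3 cells (Homo sapiens) for antiproliferative activity, read by MTT assay, with a stated time of 48 h; on this read-out lower numbers stand for stronger inhibition and higher numbers for weaker inhibition. Compound 1, `CC1(C)Cc2c(ccc(C(=O)/C=C/c3cn(-c4ccccc4)nc3-c3ccc(Cl)cc3)c2OCc2ccccc2)O1`, gives 26000 nM in this assay. Compound 2, `COc1ccc(-c2nn(-c3ccccc3)cc2/C=C/C(=O)c2ccc3c(c2OCc2ccccc2)CC(C)(C)O3)cc1`, gives 18400 nM in this assay. Compound 3, `COc1ccc(/C=C/C(=O)c2ccc(OCc3ccccc3)c3c2OC(C)(C)C3)cc1`, gives 13500 nM in this assay; its number sits within the scatter of the other two, so no order among the three can be read from these data.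

Compound 1 and compound 2 differ in one place, by chloro in place of methoxy on an aromatic carbon, and that change gave a 1.4-fold higher number from compound 2 to compound 1 (0.15 log units; within the scatter).

Compound 4, `CC1(C)Cc2c(OCc3ccccc3)ccc(C(=O)/C=C/c3ccc(Cl)cc3)c2O1`, has not yet been measured. It differs from compound 3 by chloro in place of methoxy on an aromatic carbon. This is the same change as between compound 2 and compound 1, at the same kind of place on the ring. How the core of compound 3 differs from the core of compound 2 is not broken down here.

Because the earlier instance of this change gave a 1.4-fold higher number from compound 2 to compound 1 (0.15 log units; within the scatter), compound 4 is expected to show a 1.3-fold higher number from compound 3 to compound 4 (0.10 log units; within the scatter), a step within the scatter. Compound 4 is estimated to give 17000 nM in this assay, most likely between 7000 nM and 45000 nM.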

Compound 4, half-maximal inhibitory concentration: > 100000 nM
Compound 4 was reported as a limit; the forecaster's own chance of this, stated with the estimate: 5%; middle value at least 5.8-fold (0.76 log units) from the limit.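

In this assay compound 4 gives > 100000 nM, which is a limit of the assay and not a number. Chloro in place of methoxy thus gave an at least 7.4-fold higher number from compound 3 to compound 4 (0.86 log units; beyond the scatter), and the size of the step did not carry over from one core to the other: the same change on two cores in this assay, a 1.4-fold higher number (0.15 log units; within the scatter) from compound 2 to compound 1 and an at least 7.4-fold higher number (0.86 log units; beyond the scatter) from compound 3 to compound 4, at least 5.2-fold (0.71 log units) apart, beyond the scatter of two such steps With only one pair on each core, this shows that in these four compounds the outcome of the change differed with the core, but it does not show which part of the core accounts for the gap, nor how far the activity of compound 4 lies from its limit.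

On these data alone, it remains open how a fluoro, a hydroxy or an amino group on that same aromatic carbon would read on either core. Also open, as far as these compounds go, is whether the change from 4-methoxyphenyl to 4-chlorophenyl on a further core would resemble the small step or the large one.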